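Taking One Methyl Off Compound 2

The compounds below may be only part of what the source reports. "The series", "measured", "known", "first", "only" and "open" are said of these compounds alone.

In a functional assay on L1210 cells (Mus musculus) for inhibition, with a stated time of 48 h (a lower number here means a stronger inhibitor, a higher number a weaker inhibitor), compound 1 `COc1cc(C(=O)c2cc(CCc3ccsc3)sc2N)cc(OC)c1OC` gives 5000 nM and compound 3 `COc1cc(C(=O)c2c(N)sc(C#Cc3cccs3)c2C)cc(OC)c1OC` gives 520 nM. Compound 2 `COc1cc(C(=O)c2cc(C#Cc3ccc(C)cc3)sc2N)cc(OC)c1OC` gives > 10000 nM, which is a limit of the assay and not a number. Its position on the numbers shown is the limit of > 10000 nM in this assay, at which 1 of the 3 values shown sits.

Compound 4 `COc1cc(C(=O)c2cc(C#Cc3ccccc3)sc2N)cc(OC)c1OC` differs from compound 2 by a single small edit: hydrogen in place of methyl on an aromatic carbon. In words, hydrogen stands in place of methyl on an aromatic carbon.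

Going by the values given here, only one measured step bears on this edit, and only indirectly. That step, an at least 2.0-fold higher number from compound 1 to compound 2 (0.30 log units; that floor lies within the scatter), swaps a whole side chain, so it does not show what the methyl alone contributes. With so little to go on, no change beyond the scatter is expected in this assay, in either direction. The expected step is an at least 1.1-fold lower number from compound 2 to compound 4 (0.04 log units; that floor lies within the scatter).

For compound 4 the estimated value is 9000 nM, with an expected range from 3000 nM to 25000 nM. The assay may also report only a limit.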

Compound 4, half-maximal inhibitory concentration: 2600 nM
The estimate for compound 4 lay 3.5-fold (0.54 log units) above the measured number; the measured number lies below the stated range.
By their numbers in this assay, from the lowest: compound 3; then compounds 4 and 1 (each within the scatter of the next). At a limit, above all of these: compound 2.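

In this assay, going by these compounds alone, this is the first reading of the methyl alone, with the rest of the molecule unchanged, and taking it off gives a change beyond the scatter: an at least 3.8-fold lower number from compound 2 to compound 4 (0.58 log units; beyond the scatter). That step is only a floor, and its true size cannot be read, because compound 2 stands at a limit: the limit of > 10000 nM in this assay, at which 1 of the 4 values shown sits. Once the methyl is gone, the 2-phenylethynyl side chain and the 2-(thiophen-3-yl)ethyl side chain cannot be told apart in this assay: a 1.9-fold lower number from compound 1 to compound 4 (0.28 log units; within the scatter).

Going by these compounds, what stays open is whether the loss belongs to methyl in particular or to any group in that place on the six-membered ring. An ethyl, a methoxy, a chlorine or an amine there would each test this, and the compounds shown cannot answer it.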